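A few compounds are considered here, and "the series" means these few. Any claim that something is new, unique, unknown or untested is made for them only; others in the source may bear on it.

The three measured compounds share one core and differ only in the aryl group that sits on it; compound 1 is `CCC1=C(O)c2c(oc(-c3ccc(CC)cc3)cc2=O)C(CC)(CC)C1=O`, compound 2 is `CCC1=C(O)c2c(oc(-c3cccc(C)c3)cc2=O)C(CC)(CC)C1=O` and compound 3 is `CCC1=C(O)c2c(oc(-c3cccc(F)c3)cc2=O)C(CC)(CC)C1=O`. In a functional assay on KB cells (Homo sapiens) for antiproliferative activity, read by sulforhodamine B assay, with a stated time of 3 days (a higher number here means that more compound is needed for the effect, a lower number that less compound is needed), compound 1 gives 21.9 uM. Compound 2 gives 49.7 uM in this assay. For compound 3 this assay reports no number but only a limit, > 56.2 uM. Compound 3 thus stands at the edge of what this assay can resolve, the point where (the limit of > 56.2 uM in this assay, at which 1 of the 3 values shown sits). The steps that lead to it are an at least 2.5-fold higher number from compound 1 to compound 3 (0.40 log units; beyond the scatter) and an at least 1.1-fold higher number from compound 2 to compound 3 (0.05 log units; that floor lies within the scatter), while between the two numbered compounds the step is a 2.3-fold higher number from compound 1 to compound 2 (0.36 log units; beyond the scatter).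

Compound 4, `CCC1=C(O)c2c(oc(-c3ccc(OC)cc3C)cc2=O)C(CC)(CC)C1=O`, has not yet been measured. Its change from compound 3 is 4-methoxy-2-methylphenyl in place of 3-fluorophenyl on an aromatic carbon. The fluorine whose arrival raised the number from compound 1 and from compound 2 departs, and an aryl carrying carbon and oxygen substituents, closer in kind to that of compound 1, takes its place. On the size of the step from compound 1 to compound 3, the expected move in this assay is an at least 2.2-fold lower number from compound 3 to compound 4 (0.35 log units; beyond the scatter), toward a smaller number. Compound 4 is therefore expected to give about 25 uM in this assay, most likely between 8 uM and 70 uM.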

Compound 4, concentration for half-maximal effect: 20.9 uM
Beside the measured number, compound 4's estimate is 1.2-fold (0.08 log units) above it; the range from low to high includes it.
By their numbers in this assay, from the lowest: compounds 4 and 1 (each within the scatter of the next); then compound 2. At a limit, above all of these: compound 3.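

At this aromatic carbon, next to the ring oxygen, 4-methoxy-2-methylphenyl in place of 3-fluorophenyl gives an at least 2.6-fold lower number from compound 3 to compound 4 (0.42 log units; beyond the scatter), and in place of 3-methylphenyl it gives a 2.4-fold lower number from compound 2 to compound 4 (0.38 log units; beyond the scatter), so an aryl group carrying two substituents, one of them holding oxygen, can sit here in this assay without the number rising. On these data alone, compound 3 has only a limit and no number, so the first of these steps is a floor and its full size stays unknown: the limit of > 56.2 uM in this assay, at which 1 of the 4 values shown sits. Against 4-ethylphenyl the same group gives a 1.0-fold lower number from compound 1 to compound 4 (0.02 log units; within the scatter), so this assay cannot tell these two quite different aryl groups apart, which the earlier compounds, each with a single substituent on the aryl ring, could not show.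

As far as these compounds go, compound 4 brings in its methoxy and its methyl together, so the share of each in the step stays open, as would only 4-methoxyphenyl or 2-methylphenyl alone settle. Also open, from the compounds shown here alone, is how the number would move with an amine or a carboxylic acid on this aryl ring.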